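The source may report more compounds than this note shows. Statements on the series, on what has been measured and on what is new or still open speak of the compounds shown alone.

In an assay on HT-29 cells for inhibition of Serine-protein kinase ATM (Homo sapiens), read by fluorescence, with a stated time of 1 h (on this read-out lower numbers stand for stronger inhibition and higher numbers for weaker inhibition), compound 1 `C[C@H](Nc1c(C(N)=O)nnc2ccc(-c3ccc(OCCCN(C)C)nc3)cc12)C1CCOCC1` gives 1.9 nM, and compound 2 `C[C@H](Nc1c(C(N)=O)nnc2ccc(-c3ccc(OCCCN(C)C)nc3)cc12)c1ccn(C)n1` gives 3.9 nM. Within the data shown here, the one measured step, a 2.1-fold higher number from compound 1 to compound 2 (0.31 log units; beyond the scatter), changes the group on a saturated chain carbon bound to a nitrogen on an aromatic ring and a saturated chain carbon. Among the measured compounds shown here, on these two numbers compound 2 stands highest, with compound 1 as its only neighbour, and that single step is the whole of what has been measured around it.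

Compound 3 `C[C@H](Nc1c(C(N)=O)nnc2ccc(-c3ccc(OCCCN4CCCC4)nc3)cc12)c1ccn(C)n1` keeps everything of compound 2 except (pyrrolidin-1-yl in place of dimethylamino on a saturated chain carbon, three bonds along the chain from an oxygen on an aromatic ring). No measured step touches that part of the molecule: the single measured step alters a different end of the shared core, so nothing shown bears directly on the change into compound 3. With no comparison to draw on, a step of a 1.1-fold lower number from compound 2 to compound 3 (0.05 log units; within the scatter) is expected, which is to say none beyond the scatter in this assay. Compound 3 is therefore estimated at 3.5 nM, with a range from 1.5 nM to 8 nM.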

Compound 3, half-maximal inhibitory concentration in the Serine-protein kinase ATM assay: 1.1 nM
Beside the measured number, compound 3's estimate is 3.2-fold (0.50 log units) above it; the whole stated range lies above it.
By their numbers in the Serine-protein kinase ATM assay, from the lowest: compounds 3 and 1 (each within the scatter of the next); then compound 2.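

In the Serine-protein kinase ATM assay, a 3.5-fold lower number from compound 2 to compound 3 (0.55 log units; beyond the scatter) shows that the amine end of the 3-(dimethylamino)propyl chain, which no earlier comparison touched, is not silent on this read-out when pyrrolidin-1-yl stands in place of dimethylamino. The change brings in a five-membered non-aromatic ring while the counts of hydrogen-bond donors and acceptors stay the same, and in a physicochemical assay for lipophilicity, using the shake flask method, measured as octanol-water partition, with a stated time of 30 min, at pH 7.4 (on this read-out higher numbers stand for higher lipophilicity and lower numbers for lower lipophilicity), the step of a number 0.10 log units higher from compound 2 to compound 3 (within the scatter) shows that the distribution coefficient does not separate the pair, with compound 2 at 1.7 and compound 3 at 1.8. Nothing available explains why this exchange gives a lower number in the Serine-protein kinase ATM assay.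

Among these compounds, the exchange is seen only with 1-methyl-1H-pyrazol-3-yl on the other end of the molecule, so it remains open whether it would carry over to the oxan-4-yl compound, compound 1. On these data alone, it is also open how a piperidine or a morpholine in place of the pyrrolidine, or a shorter or longer chain to the amine, would read in either assay.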